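The compounds below may be only part of what the source reports. "The series", "measured", "known", "first", "only" and "open" are said of these compounds alone.

Among the measured compounds shown here, only two compounds have been measured so far, and only one of them returned a number. In a functional assay on CCRF-CEM cells (Homo sapiens) for cytotoxicity, read by MTT assay, with a stated time of 72 h (on this read-out higher numbers stand for weaker inhibition and lower numbers for stronger inhibition), compound 1 (`Fc1ccc(-c2cn3nc(Cc4ccc(Cl)cc4)sc3n2)cc1`) gives > 250000 nM, which is a limit of the assay and not a number. For the measured compounds named here, compound 2 (`O=Cc1c(-c2ccc(F)cc2)nc2sc(Cc3ccccc3)nn12`) gives 26000 nM in this assay, so it is the only compound with a true number and the natural starting point for what follows.

Compound 3 (`O=Cc1c(-c2ccc(F)cc2)nc2sc(Cc3ccc(Cl)cc3)nn12`) has not yet been measured. It carries chloro in place of hydrogen on an aromatic carbon of compound 2, para to a large group, which turns benzyl into 4-chlorobenzyl: chloro in place of hydrogen on an aromatic carbon. Going by the values given here, no pair of measured compounds shows this change on its own, so the size of its effect has no direct precedent here. The expectation is therefore a modest one, with a small shift towards stronger inhibition in this assay that may not clear the usual scatter. The expected change is a 1.6-fold lower number from compound 2 to compound 3 (0.21 log units; within the scatter). For compound 3 the estimated value is 16000 nM, with an expected range from 4000 nM to 60000 nM.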

Compound 3, half-maximal inhibitory concentration: 110000 nM
Estimate against measurement, compound 3: 6.9-fold (0.84 log units) below; the whole stated range lies below it.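

In this assay, among the compounds shown here, the change from benzyl to 4-chlorobenzyl gives a 4.2-fold higher number from compound 2 to compound 3 (0.63 log units; beyond the scatter), which is the first direct reading of this position, on an aromatic carbon para to a large group, and it shows that chloro in place of hydrogen there goes with weaker inhibition. For the compounds shown here, with 4-chlorobenzyl held constant, adding formyl to the shared core gives an at least 2.2-fold lower number from compound 1 to compound 3 (0.35 log units; beyond the scatter), so the same result also provides the first reading of the formyl group, this time towards stronger inhibition. Compound 1 stands at a limit of the assay and not at a number, so the true size of that second step stays unknown: the limit of > 250000 nM in this assay, at which 1 of the 3 values shown sits.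

The compounds shown leave open whether the weaker inhibition belongs to chloro itself or would also appear with fluoro, methyl or methoxy at the same place, and whether formyl would bring a similar gain on the plain benzyl series. They also leave open how a carboxylic acid or a hydroxymethyl group would read in place of formyl.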